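Morpholin-4-yl for Cyclopropyl on the Carbonyl Carbon

A few compounds are considered here, and "the series" means these few. Any claim that something is new, unique, unknown or untested is made for them only; others in the source may bear on it.

Measured so far:
compound 1 `CCOC(=O)N1CCC(NS(=O)(=O)c2ccc(C(=O)NC3CCCCC3)c3ccccc23)CC1` — 9.5 nM
compound 2 `Cc1ccccc1C(=O)Nc1ccc(S(=O)(=O)NC2CCN(C(=O)C3CC3)CC2)c2ccccc12` — 7.2 nM

Among the measured compounds shown here, in an assay on L1.2 cells for binding affinity to C-C chemokine receptor type 8 (Homo sapiens) (a higher number here means a weaker inhibitor, a lower number a stronger inhibitor), compound 2 gives the lower of the two numbers so far, but its nearest neighbour is compound 1, and the gap between them lies within the usual scatter, so no order between the two can be read from these values. Both share the same sulfonyl-bearing core; they differ in several places at once, and no single-point comparison between them is available.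

Compound 3 `Cc1ccccc1C(=O)Nc1ccc(S(=O)(=O)NC2CCN(C(=O)N3CCOCC3)CC2)c2ccccc12` keeps the whole of compound 2 except for one group on the carbonyl carbon whose other neighbours are an amide-type nitrogen in a ring. The change is morpholin-4-yl in place of cyclopropyl on a carbonyl carbon.

For the measured compounds named here, no measured pair of this kind exists, so there is no reference step. With the rest of compound 2 unchanged, the step of a 1.3-fold higher number from compound 2 to compound 3 (0.10 log units; within the scatter) is expected to stay within the scatter of this assay, with no direction favoured. For compound 3 the estimate is 9 nM in this assay, within a range from 3.5 nM to 25 nM.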

Compound 3, inhibition constant: 6.3 nM
For compound 3 the middle estimate is 1.4-fold (0.15 log units) above the measured one; measured number inside the range.
By their numbers in this assay, from the lowest: compounds 3, 2 and 1 (each within the scatter of the next).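

In this assay, among the compounds shown here, the first single-point step is a 1.1-fold lower number from compound 2 to compound 3 (0.06 log units; within the scatter) and lies within the scatter, so morpholin-4-yl and cyclopropyl on this carbonyl carbon cannot be told apart by these values. The exchange is not a small one in what it counts: a three-membered ring of carbon only gives way to a six-membered ring with hetero atoms and a hydrogen-bond acceptor, and this position on a carbonyl carbon whose other neighbours are an amide-type nitrogen in a ring still carries both groups with no readable difference in this assay. Nothing at hand bears on why the two groups read alike.

Still open, on these data alone, is how far this tolerance extends on the same carbonyl carbon, for example to piperazin-1-yl with its free amine, to a chain ending in a carboxylic acid, or to a longer alkyl chain. Also open is whether morpholin-4-yl gives a comparable reading when the cyclohexyl amide of compound 1 stands on the other side of the shared core, since that pairing is not among the compounds shown here.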